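What a 4-nitrophenyl swap may do to cytotoxicity

The source may hold more compounds than are shown below. What is called first, only, known or untested is meant among the compounds shown, and "the series" means these compounds.

In a functional assay on A549 cells (Homo sapiens) for cytotoxicity, read by MTT assay, with a stated time of 24 h (on this read-out higher numbers stand for weaker inhibition and lower numbers for stronger inhibition), compound 1 `COc1ccc(/C=C(\C#N)C(=O)N/N=C(\C)c2c(O)c3ccc(O)cc3oc2=O)cc1OC` gives 14300 nM. Compound 2 `COc1cc(/C=C(\C#N)C(=O)N/N=C(\C)c2c(O)c3ccc(O)cc3oc2=O)cc(OC)c1OC` gives 15300 nM, and compound 3 `C/C(=N\NC(=O)/C(C#N)=C/c1cccc([N+](=O)[O-])c1)c1c(O)c2ccc(O)cc2oc1=O` gives 21900 nM. Compound 1 therefore cannot be told apart from either of the other two, since neither step away from it leaves the usual scatter of repeated measurements.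

Compound 4 `C/C(=N\NC(=O)/C(C#N)=C/c1ccc([N+](=O)[O-])cc1)c1c(O)c2ccc(O)cc2oc1=O` has not yet been measured. Its difference from compound 1 is this: 4-nitrophenyl in place of 3,4-dimethoxyphenyl on a double-bonded chain carbon bound to a double-bonded chain carbon. Put simply, 4-nitrophenyl stands in place of 3,4-dimethoxyphenyl, on a double-bonded chain carbon bound to a double-bonded chain carbon, while the rest of the molecule stays the same.

For the measured compounds named here, two measured steps bear on this change. The closer guide is the exchange of the same 3,4-dimethoxyphenyl for 3-nitrophenyl, which gave a 1.5-fold higher number from compound 1 to compound 3 (0.19 log units; within the scatter). The other is a methoxy in place of hydrogen on an aromatic carbon, which gave a 1.1-fold higher number from compound 1 to compound 2 (0.03 log units; within the scatter). Going by the values given here, neither step is large, so no shift beyond the scatter is expected here, though only three compounds support this view. In this assay, the estimated step is a 1.3-fold higher number from compound 1 to compound 4 (0.12 log units; within the scatter).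

For compound 4, the expected value is 19000 nM, with an estimated range of 10000 nM to 36000 nM.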

Compound 4, half-maximal inhibitory concentration: 9640 nM
Compound 4: the middle estimate sits 2.0-fold (0.29 log units) above what was measured; measured number below the stated range.
By their numbers in this assay, from the lowest: compounds 4, 1, 2 and 3 (each within the scatter of the next, the first and the last beyond it).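

In this assay, the exchange of 3,4-dimethoxyphenyl for 4-nitrophenyl on this chain carbon remains a small change, with (a 1.5-fold lower number from compound 1 to compound 4 (0.17 log units; within the scatter)), so these two groups cannot be told apart here. The new information comes from the two nitro compounds, which differ only in where the phenyl ring carries its nitro group: the comparison gives (a 2.3-fold lower number from compound 3 to compound 4 (0.36 log units; beyond the scatter)), a modest step, but the only listed one that leaves the scatter. At this place, then, the arrangement of a group on the ring can change the number even when the group itself stays the same, and nothing available explains why.

The compounds shown leave open whether this gap between 3-nitrophenyl and 4-nitrophenyl also appears with other groups, since one pair is the only evidence for it. They also leave open what a phenyl ring carrying an amine or a carboxylic acid would give on this double-bonded chain carbon, with the rest of the molecule unchanged.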